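The source may report more compounds than this note shows. Statements on the series, on what has been measured and on what is new or still open speak of the compounds shown alone.

Among the measured compounds shown here, compound 3 `Cc1ccc2oc(-c3cccc(C[C@H](O)/C=C/[C@H]4CCC(=O)N4CCSc4nc(C(=O)O)cs4)c3)nc2c1` gives 1300 nM in an assay on CHO cells for displacement of a labelled ligand from prostaglandin E2 receptor EP1 subtype (Mus musculus), read by scintillation counting, with a stated time of 20 min (a higher number here means a weaker inhibitor, a lower number a stronger inhibitor), the lowest of the three numbers measured so far. Compound 1 `O=C(O)c1csc(SCCN2C(=O)CC[C@@H]2/C=C/[C@@H](O)Cc2cccc(-c3ccccc3)c2)n1` gives 4200 nM in this assay, and compound 2 `O=C(O)c1csc(SCCN2C(=O)CC[C@@H]2/C=C/[C@@H](O)Cc2cccc(-c3ccc(Cl)cc3)c2)n1` gives 6300 nM. The steps of a 3.2-fold lower number from compound 1 to compound 3 (0.51 log units; beyond the scatter) and a 4.8-fold lower number from compound 2 to compound 3 (0.69 log units; beyond the scatter) both lie beyond the scatter, whereas a 1.5-fold higher number from compound 1 to compound 2 (0.18 log units; within the scatter) is a small step. Compound 4 `Cc1cccc2oc(-c3cccc(C[C@H](O)/C=C/[C@H]4CCC(=O)N4CCSc4nc(C(=O)O)cs4)c3)nc12` differs from compound 3 only in the change (4-methyl-1,3-benzoxazol-2-yl in place of 5-methyl-1,3-benzoxazol-2-yl on an aromatic carbon). For the measured compounds named here, no measured step bears directly on this: the steps seen so far exchange one aryl group for another or add a chloro, and none moves a methyl within the same ring. In this assay the expected step is therefore a 1.1-fold higher number from compound 3 to compound 4 (0.03 log units; within the scatter), nothing beyond the scatter. Compound 4 is estimated at 1400 nM, with a range from 500 nM to 4000 nM.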

Compound 4, inhibition constant: 7700 nM
Compound 4: middle estimate off by 5.5-fold (0.74 log units), on the low side; measured number above the stated range.
By their numbers in this assay, from the lowest: compound 3; then compounds 1, 2 and 4 (each within the scatter of the next).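

In this assay, among the compounds shown here, replacing 5-methyl-1,3-benzoxazol-2-yl with 4-methyl-1,3-benzoxazol-2-yl uses the same atoms joined differently, yet gives a 5.9-fold higher number from compound 3 to compound 4 (0.77 log units; beyond the scatter), so the place of this one methyl matters in a way no earlier step could show. The advantage of compound 3 over the phenyl and 4-chlorophenyl compounds does not carry over: a 1.8-fold higher number from compound 1 to compound 4 (0.26 log units; within the scatter) and a 1.2-fold higher number from compound 2 to compound 4 (0.09 log units; within the scatter) both stay within the scatter. Nothing measured here explains the effect of moving the methyl.

Still open, on these data alone, is how 1,3-benzoxazol-2-yl with no methyl, or with a methoxy group in place of the methyl, would compare with compound 3.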